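Urea in place of lactam: a step back toward the carbamate

The compounds below may be only part of what the source reports. "The series", "measured", "known", "first", "only" and "open" are said of these compounds alone.

Of the compounds shown here, three sharing one core have been measured in a functional assay on U2OS cells for antagonist activity at proto-oncogene Wnt-3 (Homo sapiens), read by a luciferase reporter, with a stated time of 18 h; on this read-out higher numbers stand for an effect only at larger amounts of compound and lower numbers for an effect already at smaller amounts. Compound 1 `CC(C)(C)OC(=O)N1CCC[C@H]1C(=O)N1CCC(NS(=O)(=O)c2cc(S(=O)(=O)c3ccccc3)ccc2C(F)(F)F)CC1` gives 60 nM. Compound 2 `O=C1CC[C@@H](C(=O)N2CCC(NS(=O)(=O)c3cc(S(=O)(=O)c4ccccc4)ccc3C(F)(F)F)CC2)N1` gives 240 nM, the second highest of the three numbers; its nearest neighbour is compound 3 `O=C([C@@H]1CCCN1C(=O)c1ccncc1)N1CCC(NS(=O)(=O)c2cc(S(=O)(=O)c3ccccc3)ccc2C(F)(F)F)CC1`, which gives 350 nM, a gap that lies within the scatter, while compound 1 stands furthest from it, beyond the scatter. The two steps that start from compound 1 are a 4.0-fold higher number from compound 1 to compound 2 (0.60 log units; beyond the scatter) and a 5.8-fold higher number from compound 1 to compound 3 (0.77 log units; beyond the scatter).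

Compound 4 `CC(C)(C)NC(=O)N1CCC[C@H]1C(=O)N1CCC(NS(=O)(=O)c2cc(S(=O)(=O)c3ccccc3)ccc2C(F)(F)F)CC1` is the next compound to be examined. It differs from compound 2 in one place: 1-((tert-butyl)carbamoyl)pyrrolidin-2-yl in place of 5-oxopyrrolidin-2-yl on a carbonyl carbon. The group that enters carries a tert-butyl on a carbamoyl nitrogen, which makes compound 4 closely resemble compound 1, whose pyrrolidine carries a tert-butoxycarbonyl instead. The step that bears most directly on this change is therefore a 4.0-fold higher number from compound 1 to compound 2 (0.60 log units; beyond the scatter), read in reverse, and a lower number of roughly that size is expected for compound 4, since compound 1 gives 60 nM. The expected step is a 3.0-fold lower number from compound 2 to compound 4 (0.48 log units; beyond the scatter). Compound 4 is estimated to give 80 nM in this assay, with a range from 30 nM to 250 nM.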

Compound 4, half-maximal effective concentration: 30 nM
Beside the measured number, compound 4's estimate is 2.7-fold (0.43 log units) above it; low and high end bracket the measured number.
By their numbers in this assay, from the lowest: compounds 4 and 1 (each within the scatter of the next); then compounds 2 and 3 (each within the scatter of the next).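

On the carbonyl carbon whose other neighbour is the amide-type nitrogen in a ring, 1-((tert-butyl)carbamoyl)pyrrolidin-2-yl in place of 5-oxopyrrolidin-2-yl gives an 8.0-fold lower number from compound 2 to compound 4 (0.90 log units; beyond the scatter), and (tert-butyl)amino in place of pyridin-4-yl gives a 12-fold lower number from compound 3 to compound 4 (1.07 log units; beyond the scatter), the largest step among these four compounds in this assay. The step with (tert-butyl)amino in place of tert-butoxy, a 2.0-fold lower number from compound 1 to compound 4 (0.30 log units; within the scatter), lies within the scatter, so the low number of compound 1 is not tied to its tert-butoxy group: in this series, a tert-butyl attached through either a nitrogen or an oxygen gives numbers clearly lower than those of compound 2 and compound 3. Nothing measured here explains why these groups differ, so the result records a change in the read-out and not its cause. What the compounds shown leave open is whether the tert-butyl itself matters, since none carries a methyl, a cyclopropyl or a phenyl on the carbamoyl nitrogen. They also leave open how the read-out would respond to a simple amine, such as dimethylamino, on that same carbonyl carbon.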